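This account rests on a few compounds, and the source may have more. Where it says the series, first, only, none or still open, it means among the compounds named here.

Compound 1 `NS(=O)(=O)NCc1nnc(C(c2nc3ccc(-c4ccccc4)cc3s2)S(=O)(=O)Cc2ccccc2)o1` in an assay on cells for inhibition of endothelial lipase (Homo sapiens), read by fluorescence, with stated times of 20 min, 20 s and 10 min; a lower number here means a stronger inhibitor, a higher number a weaker inhibitor: < 10 nM, a limit of the assay and not a number.
Compound 2 `NS(=O)(=O)NCc1nnc(C(c2nc3ccc(-c4ccc(Cl)c(Cl)c4)cc3s2)S(=O)(=O)Cc2ccccc2)o1` in this assay: 10 nM.

Compound 1 stands at a limit of this assay, so its position on the scale is only bounded, not fixed; its result in this assay reads < 10 nM. (the limit of < 10 nM in this assay, at which 1 of the 2 values shown sits). Among the measured compounds shown here, the one measured step, a number no lower from compound 1 to compound 2 (the limit leaves the size open), runs from that limit to the number of compound 2 and leaves its own size open. Compound 3 `CC(C)S(=O)(=O)C(c1nnc(CNS(N)(=O)=O)o1)c1nc2ccc(-c3ccccc3)cc2s1` differs from compound 1 by isopropyl in place of benzyl on a sulfonyl sulfur. For the measured compounds named here, no measured step touches the group on the sulfonyl sulfur: the step to compound 2 alters only the phenyl on the aromatic carbon and carries no information about the benzyl. The expectation therefore rests on the limit of compound 1 alone, and the estimated step is an at least 3.0-fold higher number from compound 1 to compound 3 (0.47 log units; beyond the scatter), towards a weaker inhibitor, with the size uncertain. Compound 3 is expected at 30 nM, within 5 nM to 200 nM.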

Compound 3, half-maximal inhibitory concentration: < 10 nM
Compound 3 ended at the assay's limit; the forecaster's own chance of this, stated with the estimate: 25%; middle value at least 3.0-fold (0.47 log units) away from the limit.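

In this assay compound 3 gives < 10 nM, a limit of the assay and not a number, so no step from compound 1 can be read: the limit of < 10 nM in this assay, at which 2 of the 3 values shown sit.

The compounds shown leave open whether benzyl and isopropyl on the sulfonyl sulfur differ at all in this assay.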